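Moving the Hydroxyl Group on the Anilino Ring

The compounds below may be only part of what the source reports. "The series", "measured", "known", "first", "only" and "open" are said of these compounds alone.

Compound 2 `Oc1ccc(Nc2nc(-c3cccc(F)c3)nc3ccc(F)cc23)cc1` was tested in a functional assay on MCF7 cells (Homo sapiens) for cytotoxicity, read by MTT assay, with a stated time of 48 h; on this read-out higher numbers stand for weaker inhibition and lower numbers for stronger inhibition. In this assay compound 2 gives > 50000 nM, which is a limit of the assay and not a measured number. Compound 1 `Fc1cccc(-c2nc(Nc3cccc(Cl)c3)c3cc(F)ccc3n2)c1` is its closest measured relative, differing only in the group on a nitrogen on an aromatic ring. In this assay compound 1 gives > 50000 nM, again a limit rather than a number. The step that the two limits leave unreadable from compound 1 to compound 2 therefore cannot be read; what is known is only (the limit of > 50000 nM in this assay, at which 2 of the 2 values shown sit). Compound 3 `Oc1ccccc1Nc1nc(-c2cccc(F)c2)nc2ccc(F)cc12` differs from compound 2 by 2-hydroxyphenyl in place of 4-hydroxyphenyl on a nitrogen on an aromatic ring. For the measured compounds named here, the one step that bears on this change, a step that the two limits leave unreadable from compound 1 to compound 2, tells nothing of size or direction, because both of its ends sit at the limit of > 50000 nM in this assay, at which 2 of the 2 values shown sit. With no readable step to build on, the best that can be done is to carry compound 2 forward, so the expected step of a number no higher from compound 2 to compound 3 (the limit leaves the size open) is none beyond the scatter. Compound 3 is thus estimated at 50000 nM in this assay, with a range from 15000 nM to 150000 nM, and the most likely outcome is that the assay again reports only a limit.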

Compound 3, half-maximal inhibitory concentration: > 50000 nM
Compound 3 gave a limit, no number (the forecaster's own chance of this, stated with the estimate: 75%); the middle value lies on the limit itself.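

In this assay compound 3 gives > 50000 nM, which is a limit of the assay and not a number. The steps linking compound 3 with compound 1 and compound 2 therefore cannot be read: the limit of > 50000 nM in this assay, at which 3 of the 3 values shown sit.

The compounds shown leave open whether moving the hydroxyl group on the anilino ring, or replacing 3-chlorophenyl, changes cytotoxicity at all.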